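Removing the chloro group from compound 1: an untested step

The compounds below may be only part of what the source reports. "The series", "measured", "known", "first", "only" and "open" are said of these compounds alone.

Compound 1, `CN(C)c1nc(N)c(C(=O)Nc2ccccn2)nc1Cl`, is the second highest of three numbers in an assay on Ltk cells for inhibition of metabotropic glutamate receptor 5 (Homo sapiens), read by fluorescence (a higher number here means a weaker inhibitor, a lower number a stronger inhibitor), where compound 1 gives 134 nM. Its nearest neighbour is compound 2, `CN(C)c1ncc(C(=O)Nc2ccccn2)nc1Cl`, which gives 158 nM; the step of a 1.2-fold higher number from compound 1 to compound 2 (0.07 log units; within the scatter). Far from both stands compound 3, `Nc1ncc(Cl)nc1C(=O)Nc1ccccn1`, which gives 11 nM; the step of a 12-fold lower number from compound 1 to compound 3 (1.09 log units; beyond the scatter).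

Compound 4, `CN(C)c1cnc(C(=O)Nc2ccccn2)c(N)n1`, differs from compound 1 in a single way: hydrogen in place of chloro on an aromatic carbon. The two measured steps bear only indirectly on this change. Taking away the amino group barely moved the number, while taking away the dimethylamino group lowered it strongly. Neither step touches the chloro group, which compound 1, compound 2 and compound 3 all keep, so there is no measured guide for what its removal does in this assay.

In the absence of a direct comparison, a modest weakening is expected for compound 4, within or close to the scatter, giving an estimated step of a 2.1-fold higher number from compound 1 to compound 4 (0.32 log units; beyond the scatter). Compound 4 is therefore expected to give about 280 nM, in a range from 70 nM to 1100 nM.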

Compound 4, half-maximal inhibitory concentration: 5080 nM
Compound 4: middle estimate off by 18-fold (1.26 log units), on the low side; measured number outside the range, above it.
By their numbers in this assay, from the lowest: compound 3; then compounds 1 and 2 (each within the scatter of the next); then compound 4.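

In this assay, the chloro group on this aromatic carbon, ortho to a dimethylamino group and next to the ring nitrogen, proves to matter a great deal: replacing it with hydrogen gives a 38-fold higher number from compound 1 to compound 4 (1.58 log units; beyond the scatter). The earlier compounds shown here all kept the chloro group, so they could show only what happens when the amino or dimethylamino group goes; removing the amino group, for example, gave a 1.2-fold higher number from compound 1 to compound 2 (0.07 log units; within the scatter), whereas the loss of this single chlorine atom makes compound 4 a much weaker inhibitor than compound 1. No measurement shown here explains why one atom at this position counts for so much.

Going by these compounds, it remains open whether this position needs chloro itself or would tolerate another group, such as bromo, methyl or nitrile. On these data alone, it is also open whether hydrogen in place of chloro would cost as much on compound 3, which has no dimethylamino group and gives 11 nM.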